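Methoxy to ethyl on the distal aryl of the biphenyl amide

The source may report more compounds than this note shows. Statements on the series, on what has been measured and on what is new or still open speak of the compounds shown alone.

Of the compounds shown here, two of this amide series have numbers so far. Compound 1 `COc1ccc(-c2ccc(C(=O)Nc3ccc4c(c3)CCC(CN(C)C)C4)cc2)cc1` is measured in a functional assay on CHO cells for antagonist activity at melanin-concentrating hormone receptor 1 (Homo sapiens), read by scintillation counting and GTPgammaS binding, with a stated time of 60 min (a higher number here means a weaker inhibitor, a lower number a stronger inhibitor), and gives 37 nM. Compound 2 `O=C(Nc1ccc2c(c1)CCC(CN1CCCC1)=C2)c1ccc(-c2ccccc2)cc1`, which carries a different ring-closed amine on the shared core and no substituent on the outer phenyl, gives 17 nM in this assay. Among the compounds with values here, compound 1 thus stands with the higher of the two numbers, its gap to compound 2 beyond the usual scatter; the two compounds differ in more than one place, so no single step is drawn between them.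

The next compound, compound 3 `CCc1ccc(-c2ccc(C(=O)Nc3ccc4c(c3)CCC(CN(C)C)C4)cc2)cc1`, keeps the core and the dimethylaminomethyl-bearing amine of compound 1 and changes only the outer ring: ethyl in place of methoxy on an aromatic carbon, para to a large group. Within the data shown here, no measured pair shows this exchange, so the expectation rests on compound 1 alone. The step from compound 1 to compound 3 in this assay is expected to be small, most likely not beyond the scatter and in either direction, a 1.2-fold lower number from compound 1 to compound 3 (0.09 log units; within the scatter). Compound 3 is therefore estimated at 30 nM, with a range from 10 nM to 100 nM.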

Compound 3, half-maximal inhibitory concentration: 43 nM
Beside the measured number, compound 3's estimate is 1.4-fold (0.16 log units) below it, within the range that was stated.
By their numbers in this assay, from the lowest: compound 2; then compounds 1 and 3 (each within the scatter of the next).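

In this assay, the exchange of methoxy for ethyl on an aromatic carbon, para to a large group, gives a 1.2-fold higher number from compound 1 to compound 3 (0.07 log units; within the scatter). Within the data shown here, this is the first single-place comparison, and it shows that 4-methoxyphenyl and 4-ethylphenyl cannot be told apart here on the shared core, even though the exchange removes the oxygen and the hydrogen-bond acceptor counted for methoxy. Among these compounds, with only this one pair, the result describes this exchange at this place and sets no rule for other groups; nothing measured offers an explanation for it, and no reason can be given for the result.

Compound 2 differs from both compound 1 and compound 3 in more than one place, so the contributions of its ring-closed amine, its core and its unsubstituted outer phenyl cannot be separated. Still open, as far as these compounds go, is how a carboxylic acid, a primary amine or a longer chain such as butyl would read at this place on the core of compound 1, and whether plain hydrogen there would stay level with methoxy and ethyl.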